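The compounds below may be only part of what the source reports. "The series", "measured", "known", "first", "only" and "open" are said of these compounds alone.

Of the compounds shown here, three have been tested so far. In a functional assay on OVCAR-8 cells (Homo sapiens) for inhibition, read by sulforhodamine B assay, with a stated time of 48 h (a lower number here means a stronger inhibitor of growth, a higher number a weaker inhibitor of growth), compound 1 (`CN(C)/C=C/C(=O)c1nn(-c2ccccc2)c(-c2ccccc2)c1C#N`) gives 75800 nM as its result. Compound 2 (`Cc1nnc(-c2nn(-c3ccccc3)c(-c3ccccc3)c2C#N)c2cn(-c3ccccc3)nc12`) returns > 100000 nM as its result, which is a limit of the assay and not a number. Compound 3 (`N#Cc1c(-c2nnc(-c3nn(-c4ccccc4)c(-c4ccccc4)c3C#N)c3nn(-c4ccccc4)cc23)nn(-c2ccccc2)c1-c1ccccc1`) gives 9820 nM and holds the lowest number of the set. Compound 1, its nearest neighbour on the scale, stands higher by a margin beyond the usual scatter of repeat measurements.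

Compound 4 (`N#Cc1c(-c2nnc(-c3nn(-c4ccccc4)c(-c4ccccc4)c3C#N)c3nn(-c4ccc(Cl)cc4)cc23)nn(-c2ccccc2)c1-c1ccccc1`) has not yet been measured. It differs from compound 3 in one place, where phenyl becomes 4-chlorophenyl, with chloro in place of hydrogen on an aromatic carbon and the rest of the molecule unchanged. Among the compounds with values here, no two tested compounds differ in just one place, so the data offer no direct guide to the size of this change. The shift expected in this assay is therefore modest, perhaps slightly towards a lower number and quite possibly within the scatter. Compound 3 at 9820 nM is the starting point for this estimate. The expected move is a 1.2-fold lower number from compound 3 to compound 4 (0.09 log units; within the scatter) in this estimate. Compound 4 is expected at 8000 nM with an estimated range from 3000 nM to 25000 nM for a measurement.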

Compound 4, concentration for 50% growth inhibition: 61800 nM
Compound 4: middle estimate off by 7.7-fold (0.89 log units), on the low side; the measured number lies above the stated range.
By their numbers in this assay, from the lowest: compound 3; then compounds 4 and 1 (each within the scatter of the next). At a limit, above all of these: compound 2.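

Within the data shown here, this is the first pair in the set that differs in only one place, so it gives the first direct reading of a change on one of these rings: in this assay, putting chloro in place of hydrogen, turning phenyl into 4-chlorophenyl, gives a 6.3-fold higher number from compound 3 to compound 4 (0.80 log units; beyond the scatter). The step lies beyond the scatter and points towards weaker inhibition of growth, so this place on the molecule is not indifferent to substitution, even though the change adds just one heavy atom, with no ring, no charge and no hydrogen-bond donor or acceptor. Nothing measured here gives a reason for this loss.

Compound 4 is the only compound shown with a substituent on this ring, so a single step cannot tell whether the loss is specific to chloro or whether fluoro, methoxy or an amine at the same place would move the number in the same direction and by a similar amount. Going by these compounds, it also remains open whether chloro on one of the other phenyl rings of compound 3 would have the same effect, or whether chloro elsewhere on this ring would.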